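Benzofuran in Place of Furan on a Nucleoside Core

This account rests on a few compounds, and the source may have more. Where it says the series, first, only, none or still open, it means among the compounds named here.

Measured so far:
Compound 1, `Cc1ncnc2c1c(-c1cc3ccccc3o1)cn2[C@@H]1O[C@H](CO)[C@@H](O)[C@H]1O`: in a functional assay on HeLa S3 cells (Homo sapiens) for antiproliferative activity, read by XTT assay, with a stated time of 72 h (on this read-out higher numbers stand for weaker inhibition and lower numbers for stronger inhibition), compound 1 gives > 20000 nM, which is a limit of the assay and not a number.
Compound 2, `Cc1ncnc2c1c(-c1ccoc1)cn2[C@@H]1O[C@H](CO)[C@@H](O)[C@H]1O`: in this assay compound 2 gives > 20000 nM, again a limit of the assay.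
Compound 3, `Cc1nc(N)c2c(-c3ccoc3)cn([C@@H]3O[C@H](CO)[C@@H](O)[C@H]3O)c2n1`: in this assay compound 3 gives > 20000 nM, also a limit of the assay.

Compound 1 and compound 2 share one core and differ in one place: 1-benzofuran-2-yl in place of furan-3-yl on an aromatic carbon. On these data alone, because both values sit at the limit of > 20000 nM in this assay, at which 3 of the 3 values shown sit, the step that the two limits leave unreadable from compound 2 to compound 1 cannot be read, and its size stays unknown. The difference between the core of compound 2 and the core of compound 3 is not broken down here.

Compound 4, `Cc1nc(N)c2c(-c3cc4ccccc4o3)cn([C@@H]3O[C@H](CO)[C@@H](O)[C@H]3O)c2n1`, has not yet been measured. It is related to compound 3 by the same change that turns compound 2 into compound 1: 1-benzofuran-2-yl in place of furan-3-yl on an aromatic carbon. The two place descriptions are the same word for word, so this is the same change on a different core. Only limits are known for the parent pair, so the step from compound 3 to compound 4 in this assay is expected to be no more readable than the earlier one, and is estimated at a step that the limit leaves unreadable from compound 3 to compound 4 because the earlier step that the two limits leave unreadable from compound 2 to compound 1 gave no number. Compound 4 is therefore expected to stay at the limit, with an estimate of 30000 nM and a range from 10000 nM to 100000 nM.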

Compound 4, half-maximal inhibitory concentration: > 20000 nM
Compound 4: only a limit was reported; the forecaster's own chance of this, stated with the estimate: 85%; the middle value is on the limit's open side.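

In this assay compound 4 gives > 20000 nM, which is a limit of the assay and not a number. The step from compound 3 to compound 4 therefore cannot be read, because both compounds sit at the same limit: the limit of > 20000 nM in this assay, at which 4 of the 4 values shown sit.

The compounds shown leave open whether 1-benzofuran-2-yl in place of furan-3-yl changes antiproliferative activity at all, on either core.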